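This account rests on a few compounds, and the source may have more. Where it says the series, first, only, none or still open, it means among the compounds named here.

Measured so far in a functional assay on B16 cells (Mus musculus) for antiproliferative activity, with a stated time of 72 h; a lower number here means a stronger inhibitor, a higher number a weaker inhibitor:
- compound 1 `OC[C@H]1O[C@@H](n2cnc3c(NCc4ccc(Cl)c(Cl)c4)ncnc32)[C@H](O)[C@@H]1O`: > 166000 nM, a limit
- compound 2 `COc1cc(CNc2ncnc3c2ncn3[C@@H]2O[C@H](CO)[C@@H](O)[C@H]2O)cc(OC)c1`: "not determined" (no result reported)
- compound 3 `OC[C@H]1O[C@@H](n2cnc3c(NCc4c(F)ccc(F)c4F)ncnc32)[C@H](O)[C@@H]1O`: > 166000 nM, a limit

The read-out for compound 3 is a limit and not a number: > 166000 nM. Its position in the series is therefore only that of the limit of > 166000 nM in this assay, at which 2 of the 3 values shown sit. Compound 2 adds no result.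

Next is compound 4 `OC[C@H]1O[C@@H](n2cnc3c(NCc4ccc(F)cc4Cl)ncnc32)[C@H](O)[C@@H]1O`, and the change is 2-chloro-4-fluorophenyl in place of 2,3,6-trifluorophenyl on a saturated chain carbon bound to a nitrogen on an aromatic ring. In words, 2-chloro-4-fluorophenyl comes in place of 2,3,6-trifluorophenyl on a saturated chain carbon bound to a nitrogen on an aromatic ring.

Within the data shown here, one measured step bears on this, another exchange of the phenyl group at the same place: a step that the two limits leave unreadable from compound 1 to compound 3. It gives neither a size nor a direction to carry over. In this assay, no step beyond the scatter is therefore expected, and no direction is predicted. The expected step is a step that the limit leaves unreadable from compound 3 to compound 4. Compound 4 is estimated at 170000 nM, with an expected range of 60000 nM to 300000 nM.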

Compound 4, half-maximal inhibitory concentration: > 166000 nM
Compound 4 ended at the assay's limit; the forecaster's own chance of this, stated with the estimate: 75%; the middle value does not contradict the limit.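

In this assay no step can be read among compound 1, compound 3 and compound 4: all three stand at a limit and not at a number. The compounds shown leave open whether any other phenyl group at this place brings a value inside the assay's range.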